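This account rests on a few compounds, and the source may have more. Where it says the series, first, only, none or still open, it means among the compounds named here.

Working notes on the series. In a functional assay on PC-3 cells (Homo sapiens) for antiproliferative activity, read by CCK-8 assay, with a stated time of 6 days (on this read-out lower numbers stand for stronger inhibition and higher numbers for weaker inhibition), compound 1 (`CCN(c1ccc(C#N)c(Cl)c1)c1cc(-c2ccco2)ccc1C`) gives > 30000 nM, which is a limit and not a number. Compound 2 (`CCN(c1ccc(C#N)c(Cl)c1)c1cc(-c2cncnc2)ccc1C`) gives > 30000 nM, also a limit. Compound 3 (`CCN(c1ccc(C#N)c(Cl)c1)c1cc(-c2cccs2)ccc1C`) gives > 30000 nM, again a limit, so its standing is known no better than that of the other two.

The next change puts 1H-pyrazol-1-yl in place of thiophen-2-yl on an aromatic carbon, meta to a large group and para to a methyl group, and gives compound 4 (`CCN(c1ccc(C#N)c(Cl)c1)c1cc(-n2cccn2)ccc1C`): 1H-pyrazol-1-yl in place of thiophen-2-yl on an aromatic carbon.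

Within the data shown here, the steps that bear on this change are the other ring exchanges at the same place: a step that the two limits leave unreadable from compound 1 to compound 3, a step that the two limits leave unreadable from compound 2 to compound 3 and a step that the two limits leave unreadable from compound 1 to compound 2. Among the measured compounds shown here, none has a readable size, so no measured step can be carried over. All that the three compounds share is the limit of > 30000 nM in this assay, at which 3 of the 3 values shown sit, and none of them goes against it. A step beyond the scatter in this assay is therefore not expected, and no direction can be assigned to one. The expected change is a number no higher from compound 3 to compound 4 (the limit leaves the size open). For compound 4 the estimated value is 30000 nM, with an expected range from 12000 nM to 60000 nM, and a report of the limit alone is the likeliest outcome.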

Compound 4, half-maximal inhibitory concentration: 15700 nM
For compound 4 the middle estimate is 1.9-fold (0.28 log units) above the measured one, and the stated range covers the measured number.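

At this position, meta to a large group and para to a methyl group, one ring exchange yields a readable number in this assay: compound 4 gives 15700 nM. Placing 1H-pyrazol-1-yl here gives an at least 1.9-fold lower number from compound 3 to compound 4 (0.28 log units; that floor lies within the scatter), an at least 1.9-fold lower number from compound 2 to compound 4 (0.28 log units; that floor lies within the scatter) and an at least 1.9-fold lower number from compound 1 to compound 4 (0.28 log units; that floor lies within the scatter), so each of these steps has only a floor and its true size remains unknown, while the steps among the other three compounds cannot be read. Compound 1, compound 2 and compound 3 each remain at a limit, not a number: the limit of > 30000 nM in this assay, at which 3 of the 4 values shown sit.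

The compounds shown do not tell whether the number of compound 4 belongs to 1H-pyrazol-1-yl specifically or would also be reached with 1H-imidazol-1-yl, a 1,2,4-triazol-1-yl ring, a morpholine or a carboxylic acid at the same place. They also leave open whether a step beyond the scatter can be obtained here, and how this ring would behave with a longer chain in place of the ethyl group on the shared core.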